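Adding a fluoro group to compound 2

The compounds below may be only part of what the source reports. "The series", "measured", "known", "first", "only" and "open" are said of these compounds alone.

In an ADME assay on microsomes from liver (Mus musculus) for metabolic stability, with a stated time of 10 min (a lower number here means that less of the compound is left, a higher number that more of the compound is left), compound 1 `CO[C@]1(C(=O)N2CC[C@](c3ccc(C(F)(C(F)(F)F)C(F)(F)F)cc3)(S(=O)(=O)c3ccc(F)cc3)C2)CC[C@H](C(=O)O)CC1` gives 95% and compound 2 `O=C(C1CCS(=O)(=O)CC1)N1CC[C@](c2ccc(C(F)(C(F)(F)F)C(F)(F)F)cc2)(S(=O)(=O)c2ccc(F)cc2)C1` gives 96%, so the two stand level within the scatter. Compound 3 `O=C(N1CC[C@](c2ccc(C(F)(C(F)(F)F)C(F)(F)F)cc2)(S(=O)(=O)c2ccc(F)cc2)C1)C1(F)CCS(=O)(=O)CC1` differs from compound 2 by a single change, fluoro in place of hydrogen on a saturated ring carbon. Among the compounds with values here, the only measured step, a number 1 percentage points higher from compound 1 to compound 2 (within the scatter), exchanges a whole group on a carbonyl carbon, and no measured step covers a fluoro change. No shift beyond the scatter is expected, and the estimated step is a number 2 percentage points lower from compound 2 to compound 3 (within the scatter). In this assay the estimate for compound 3 is 94%, with an expected range of 84% to 100%.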

Compound 3, percent of the compound remaining: 90%
For compound 3 the middle estimate is 4 percentage points above the measured one; the range from low to high includes it.
By their numbers in this assay, from the lowest: compounds 3, 1 and 2 (each within the scatter of the next).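

In this assay, within the data shown here, the first change at this ring carbon, fluoro in place of hydrogen, gives a number 6 percentage points lower from compound 2 to compound 3 (within the scatter), so this position takes the fluoro without a shift beyond the scatter. The exchange of the whole group for 4-fluoro-1,1-dioxothian-4-yl likewise gives a number 5 percentage points lower from compound 1 to compound 3 (within the scatter). Nothing measured here accounts for where these numbers fall.

From the compounds shown here alone, whether a hydroxyl group or an amine on the same ring carbon would also stay within the scatter of compound 2 remains open. The compounds shown also leave open how this fluoro change reads in any other assay.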